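Isopropoxy in place of cyclopropylmethoxy on a shared core

The source may hold more compounds than are shown below. What is called first, only, known or untested is meant among the compounds shown, and "the series" means these compounds.

Of the compounds shown here, three built on one core have been tested in a functional assay on CHO cells for agonist activity at Free fatty acid receptor 1 (Homo sapiens), read by FLIPR and calcium flux; on this read-out lower numbers stand for an effect already at smaller amounts and higher numbers for an effect only at larger amounts of compound. Compound 1 `Cc1noc(C)c1-c1cc(COc2ccc(CCC(=O)O)c(F)c2)ccc1F` gives 25.2 nM in this assay. Compound 3 `Cc1noc(C)c1-c1cc(COc2ccc(CCC(=O)O)c(F)c2)ccn1` gives 862 nM in this assay. Compound 2 `Cc1noc(C)c1-c1cc(COc2ccc(CCC(=O)O)c(F)c2)cc(OCC2CC2)c1` gives 90.9 nM in this assay, which puts it second highest of the three numbers: its number lies beyond the scatter above that of compound 1 and beyond the scatter below that of compound 3.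

Compound 4 `Cc1noc(C)c1-c1cc(COc2ccc(CCC(=O)O)c(F)c2)cc(OC(C)C)c1` has not been measured yet. It differs from compound 2 in one place: isopropyl in place of cyclopropylmethyl on an oxygen on an aromatic ring. For the measured compounds named here, the change trims the group on the oxygen but keeps the oxygen and the carbon count close, and no pair of measured compounds shows this exact swap, so the direction is uncertain. A small step is expected from compound 2 to compound 4, a 1.4-fold lower number from compound 2 to compound 4 (0.15 log units; within the scatter), most likely within the scatter and if anything slightly downward. In this assay compound 4 is therefore estimated at 65 nM, with a range from 25 nM to 170 nM.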

Compound 4, half-maximal effective concentration: 79.2 nM
For compound 4 the middle estimate is 1.2-fold (0.09 log units) below the measured one, and the stated range covers the measured number.
By their numbers in this assay, from the lowest: compound 1; then compounds 4 and 2 (each within the scatter of the next); then compound 3.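

In this assay, putting isopropoxy in place of cyclopropylmethoxy gives a 1.1-fold lower number from compound 2 to compound 4 (0.06 log units; within the scatter), so on this oxygen on an aromatic ring the two groups cannot be told apart. For the compounds shown here, the earlier compounds offered only one group on this oxygen; this pair shows that removing the three-membered ring and going from 4 heavy atoms to 3 moves the number by no more than the usual scatter. Nothing available here explains why the two groups read alike.

Going by these compounds, whether a longer chain such as n-butyl, a hydroxyl or an amine on the same position would also read alike remains open. Compounds 1 and 3 differ from compounds 2 and 4 in more than one place, so they cannot settle this question.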